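Dropping a Chloro from the Benzyl Group on a Shared Core

The source may report more compounds than this note shows. Statements on the series, on what has been measured and on what is new or still open speak of the compounds shown alone.

compound 1 `CC1CCN(Cc2ccc3nc(NC(=O)N/N=C/c4cn(Cc5ccc(Cl)cc5Cl)c5ccccc45)sc3c2)CC1`: 3140 nM
compound 2 `CCN(CC)Cc1ccc2nc(NC(=O)N/N=C/c3c[nH]c4ccccc34)sc2c1`: 1900 nM
compound 3 `Cc1ccc(Cn2cc(/C=N/NC(=O)Nc3nc4ccc(CN(C)C)cc4s3)c3ccccc32)cc1`: 1220 nM

In a functional assay on MDA-MB-231 cells (Homo sapiens) for cytotoxicity, read by MTT assay, with a stated time of 72 h (a lower number here means a stronger inhibitor, a higher number a weaker inhibitor), compound 1 gives the highest of the three numbers; compound 2 lies within the scatter of it, while compound 3 stands beyond the scatter with a lower number. Compound 4 `CC1CCN(Cc2ccc3nc(NC(=O)N/N=C/c4cn(Cc5ccccc5Cl)c5ccccc45)sc3c2)CC1` differs from compound 1 in one place: hydrogen in place of chloro on an aromatic carbon. Cut one bond further out, the change reads 2,4-dichlorobenzyl to 2-chlorobenzyl. Going by the values given here, no measured pair shares this change, so the outlook rests on the three values alone: compound 2 and compound 3 carry less on that side of the core and show lower numbers, though both also differ from compound 1 elsewhere. The step of a 1.3-fold lower number from compound 1 to compound 4 (0.10 log units; within the scatter) is expected to be small, toward a lower number but within the scatter. Compound 4 is expected at 2500 nM, between 1000 nM and 6000 nM.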

Compound 4, half-maximal inhibitory concentration: 1360 nM
Beside the measured number, compound 4's estimate is 1.8-fold (0.26 log units) above it, within the range that was stated.
By their numbers in this assay, from the lowest: compounds 3, 4, 2 and 1 (each within the scatter of the next, the first and the last beyond it).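

In this assay, hydrogen in place of the chloro para to a large group gives a 2.3-fold lower number from compound 1 to compound 4 (0.36 log units; beyond the scatter) as the first step read directly at this position, and it is a modest one. The 2,4-dichlorobenzyl group therefore does not need this chloro to keep its activity on the shared core, and the number falls once it leaves. Nothing shown accounts for this step.

As far as these compounds go, whether a fluoro, a bromo or a methoxy group on that same aromatic carbon would also give a lower number remains open. So does the effect of removing the remaining chloro of the 2-chlorobenzyl group.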